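Phenyl in place of neopentyl: working notes

The compounds below may be only part of what the source reports. "The series", "measured", "known", "first", "only" and "open" are said of these compounds alone.

Measured so far (a functional assay on a cell-free system (plasma, Homo sapiens), with a stated time of 3 min; on this read-out higher numbers stand for weaker inhibition and lower numbers for stronger inhibition):
- compound 1 `O=C(NCc1cc(Cl)ccc1-n1cnnn1)[C@@H]1C[C@@H]2C[C@@H]2N1C(=O)[C@H](O)CC1CC1` gives 1700 nM
- compound 2 `CC(C)(C)C[C@@H](O)C(=O)N1[C@H](C(=O)NCc2cc(Cl)ccc2-n2cnnn2)C[C@@H]2C[C@@H]21` gives 570 nM

Compound 2 holds the lower of the two numbers (570 nM). Compound 3 `O=C(NCc1cc(Cl)ccc1-n1cnnn1)[C@@H]1C[C@@H]2C[C@@H]2N1C(=O)[C@H](O)c1ccccc1` carries phenyl in place of neopentyl on a saturated chain carbon bound to a carbonyl carbon and an oxygen on a saturated carbon. Among the measured compounds shown here, the only measured step on this chain is a 3.0-fold lower number from compound 1 to compound 2 (0.47 log units; beyond the scatter) (tert-butyl in place of cyclopropyl). A step of similar modest size toward a higher number is therefore expected in this assay, though two compounds give thin support. The expected step is a 2.1-fold higher number from compound 2 to compound 3 (0.32 log units; beyond the scatter) (an estimate). Compound 3 is estimated at 1200 nM (range 300 nM to 4000 nM).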

Compound 3, half-maximal inhibitory concentration: 620 nM
For compound 3 the middle estimate is 1.9-fold (0.29 log units) above the measured one; low and high end bracket the measured number.
By their numbers in this assay, from the lowest: compounds 2 and 3 (each within the scatter of the next); then compound 1.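

In this assay, phenyl in place of neopentyl gives a 1.1-fold higher number from compound 2 to compound 3 (0.04 log units; within the scatter) and so leaves the number unchanged within the scatter, showing that this carbon accepts an aromatic ring as well as a saturated chain. Phenyl in place of cyclopropylmethyl gives a 2.7-fold lower number from compound 1 to compound 3 (0.44 log units; beyond the scatter) and is a step beyond the scatter, so compound 1 stays apart from compound 2 and compound 3. No available evidence bears on this result. Open, going by these compounds, is how a pyridine ring or a substituted phenyl would read at this carbon. On these data alone, a carboxylic acid or an amine on this carbon also remains open.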